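The source may report more compounds than this note shows. Statements on the series, on what has been measured and on what is new or still open speak of the compounds shown alone.

In a functional assay on MCF7 cells (Homo sapiens) for antiproliferative activity (on this read-out lower numbers stand for stronger inhibition and higher numbers for weaker inhibition), the measured compounds are:
Compound 1 `CC(=O)Oc1ccc2cc(-n3cc(-c4ccc(C)cc4)nn3)c(=O)oc2c1C` gives > 100000 nM (a limit).
Compound 2 `CO[C@@H]1[C@@H](O)[C@@H](O)[C@H](Oc2ccc3c(c2C)OC(=O)C(n2cc(-c4ccc(C)cc4)nn2)C3)OC1(C)C` gives > 100000 nM (a limit).

Compound 2 stands at the limit of > 100000 nM in this assay, at which 2 of the 2 values shown sit, and so has a limit, not a number. Compound 3 `CO[C@@H]1[C@@H](O)[C@@H](O)[C@H](Oc2ccc3c(c2C)OC(=O)C(n2cc(-c4ccc(N(C)C)cc4)nn2)C3)OC1(C)C` differs from compound 2 by dimethylamino in place of methyl on an aromatic carbon, and dimethylamino in place of methyl on an aromatic carbon gives the count of that change. Within the data shown here, no measured pair shows what such a change does in this assay here. The estimated step of an at least 1.6-fold lower number from compound 2 to compound 3 (0.22 log units; that floor lies within the scatter) is expected to be small and toward stronger inhibition, and the reading may well remain a limit. For compound 3 the estimate is 60000 nM with an expected range from 15000 nM to 150000 nM in all.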

Compound 3, half-maximal inhibitory concentration: > 100000 nM
Compound 3: a limit, no number (the forecaster's own chance of this, stated with the estimate: 55%); middle value at least 1.6-fold (0.22 log units) from the limit.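

In this assay compound 3 gives > 100000 nM as a limit and not a number. Among these compounds, with compound 2 also at a limit, no step from compound 2 to compound 3 can be read: the limit of > 100000 nM in this assay, at which 3 of the 3 values shown sit.

The compounds shown leave open what dimethylamino in place of methyl on an aromatic carbon does to the value, and how strongly any of them inhibits.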